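The compounds below may be only part of what the source reports. "The series", "measured", "known", "first", "only" and "open" are said of these compounds alone.

In a functional assay on MV4-11 cells (Homo sapiens) for inhibition, read by resazurin assay, with a stated time of 72 h (on this read-out lower numbers stand for stronger inhibition of growth and higher numbers for weaker inhibition of growth), compound 1 (`COc1ccc(Nc2nccc(-c3sc(SC(C)C)nc3C)n2)c(OC)c1`) gives 5670 nM and sits within the scatter of compound 3 (`COc1ccc(Nc2nccc(-c3cn(C(C)C)c4ccccc34)n2)c(OC)c1`) at 3250 nM while compound 2 (`COc1ccc(Nc2nccc(-c3c[nH]c4ccccc34)n2)c(OC)c1`) at 600 nM lies clearly lower. Compound 4 (`COc1ccc(Nc2nccc(-c3sc(OC)nc3C)n2)c(OC)c1`) has methoxy in place of isopropylsulfanyl on an aromatic carbon next to the ring nitrogen and the ring sulfur. Within the data shown here, the only measured step involving an isopropyl group is a 5.4-fold higher number from compound 2 to compound 3 (0.73 log units; beyond the scatter) and it lies on an aromatic nitrogen in a different setting, so it is a loose guide. A modest move to a lower number is expected in this assay and the estimated step is a 2.3-fold lower number from compound 1 to compound 4 (0.36 log units; beyond the scatter) on this basis. Compound 4 is estimated at 2500 nM with an expected range of 800 nM to 7500 nM for now.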

Compound 4, concentration for 50% growth inhibition: 1400 nM
Estimate against measurement, compound 4: 1.8-fold (0.25 log units) above; measured number inside the range.
By their numbers in this assay, from the lowest: compound 2; then compound 4; then compounds 3 and 1 (each within the scatter of the next).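

Working notes: in this assay the aromatic carbon next to the ring nitrogen and next to the ring sulfur responds to its substituent, with a 4.1-fold lower number from compound 1 to compound 4 (0.61 log units; beyond the scatter) on going to methoxy. The number moves with a group of 2 heavy atoms replacing one of 4, while the hydrogen-bond acceptor count stays the same. No supporting data explain this step.

Methylsulfanyl at this carbon would separate the exchange of sulfur for oxygen from the loss of the isopropyl carbons. An amine or an ethoxy chain would test how far this position tolerates other groups.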